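Does the Group on the Double-Bonded Nitrogen Matter?

A few compounds are considered here, and "the series" means these few. Any claim that something is new, unique, unknown or untested is made for them only; others in the source may bear on it.

In a functional assay on MCF7 cells (Homo sapiens) for cytotoxicity, read by sulforhodamine B assay, with a stated time of 24 h (a lower number here means a stronger inhibitor, a higher number a weaker inhibitor), compound 1 `Cc1ccc(/N=C2\C(=O)Nc3ccc(S(=O)(=O)N4CCOCC4)cc32)cc1` gives 55900 nM and compound 2 `CC(=O)N/N=C1\C(=O)Nc2ccc(S(=O)(=O)N3CCOCC3)cc21` gives 56000 nM while compound 3 `CC(=O)c1cccc(/N=C2\C(=O)Nc3ccc(S(=O)(=O)N4CCOCC4)cc32)c1` gives 39200 nM on the same test. All three share one core and differ only in the group on a double-bonded nitrogen. Compound 3 stands level with the other two, since its number cannot be told apart from theirs within the ordinary scatter of repeat measurements.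

Compound 4 `O=C1Nc2ccc(S(=O)(=O)N3CCOCC3)cc2/C1=N/c1ccc(Cl)cc1` is still unmeasured and carries 4-chlorophenyl in place of 3-acetylphenyl on a double-bonded nitrogen. The swaps already measured at this place gave a 1.0-fold higher number from compound 1 to compound 2 (0.00 log units; within the scatter) and a 1.4-fold lower number from compound 1 to compound 3 (0.15 log units; within the scatter) and a 1.4-fold lower number from compound 2 to compound 3 (0.15 log units; within the scatter) and all of them lie within the scatter. Across these three compounds, the group at this place has shown no clear effect. The estimated change is a 1.1-fold higher number from compound 3 to compound 4 (0.06 log units; within the scatter) and so no step beyond the scatter is expected in this assay here. For compound 4 the estimated value is 45000 nM with an expected range from 20000 nM to 90000 nM in this test.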

Compound 4, half-maximal inhibitory concentration: 44300 nM
Estimate against measurement, compound 4: 1.0-fold (0.01 log units) above, within the range that was stated.
By their numbers in this assay, from the lowest: compounds 3, 4, 1 and 2 (each within the scatter of the next).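

In this assay, among these compounds, compound 4 brings chlorine to this place for the first time, and the result stays level with the earlier compounds: a 1.1-fold higher number from compound 3 to compound 4 (0.05 log units; within the scatter) and a 1.3-fold lower number from compound 2 to compound 4 (0.10 log units; within the scatter). The closest comparison is chloro in place of methyl on an aromatic carbon, a swap of one substituent on an otherwise unchanged structure, and it gives a 1.3-fold lower number from compound 1 to compound 4 (0.10 log units; within the scatter). All four groups now lie within the scatter of one another, so the lack of a clear effect extends to this chlorine-bearing group, though no accompanying measurement offers an explanation for this flat result.

As far as these compounds go, whether an amine or a carboxylic acid on the phenyl ring, or a longer alkyl chain on the double-bonded nitrogen, would move the number beyond the scatter remains open. From the compounds shown here alone, all four values also come from this assay alone, so whether this place matters in other cells is unknown.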